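Antiproliferative readout after removal of an acetyl group

The source may hold more compounds than are shown below. What is called first, only, known or untested is meant among the compounds shown, and "the series" means these compounds.

Measured compounds:
- compound 1, `CC(=O)Oc1ccc(CONC(=O)c2ccc(CS(=O)(=O)Nc3ccc4cc(C)c(=O)n(C)c4c3)cc2)cc1`: 4%
- compound 2, `COC(=O)c1ccc(S(=O)(=O)Nc2ccc3c(c2)cc(C)c(=O)n3C)c(OC)c1`: 0%

Of the compounds shown here, two have been tested in a functional assay on THP-1 cells (Homo sapiens) for antiproliferative activity, tested at 1 uM; a higher number here means a stronger effect of the compound at the concentration tested, a lower number a weaker effect. Compound 1 gives 4%, the higher of the two numbers. Compound 2 gives 0%, which lies within the usual scatter of the number for compound 1, so the two compounds cannot be told apart on this readout. Going by the values given here, no pairwise step between measured compounds is available, and both numbers sit near the bottom of the scale.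

Compound 3, `Cc1cc2ccc(NS(=O)(=O)Cc3ccc(C(=O)NOCc4ccc(O)cc4)cc3)cc2n(C)c1=O`, is the untested compound. It differs from compound 1 in one place: hydrogen in place of acetyl on an oxygen on an aromatic ring. The 4-acetoxybenzyl of compound 1 becomes a 4-hydroxybenzyl in compound 3, with the rest of the molecule unchanged.

With compound 1 at 4% and nothing else to go on, compound 3 is expected to show no step beyond the scatter, that is, a change of a number 1 percentage points higher from compound 1 to compound 3 (within the scatter). Compound 3 is therefore estimated at 5% in this assay, with a range from -8% to 20%.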

Compound 3, a percentage reported as inhibition, at one concentration (the size of the read-out at that concentration, not a potency): 0%
Compound 3: middle estimate off by 5 percentage points, on the high side; the measured number falls inside the stated range.
By their numbers in this assay, from the lowest: compounds 2, 3 and 1 (each within the scatter of the next).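

In this assay, going by these compounds alone, hydrogen in place of acetyl on an oxygen on an aromatic ring gives a number 4 percentage points lower from compound 1 to compound 3 (within the scatter), and this is the first comparison in which only one place differs. At this position, going from 4-acetoxybenzyl to 4-hydroxybenzyl therefore produces no change that the read-out can separate from the usual scatter. Within the data shown here, the free hydroxy compound and its acetoxy counterpart both stay near the bottom of the scale, so at the single concentration tested this comparison gives no sign that the acetyl group matters for the effect, in either direction. Nothing available offers an explanation for this outcome. The compounds shown leave open whether another group on this oxygen or in its place, such as a methyl ether, an amine or a carboxylic acid, would lift the read-out clear of the scatter. They also leave open whether compound 1 and compound 3 would differ at a higher concentration, where the effect might no longer sit so close to the bottom of the scale.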